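From chloro to methylsulfonyl: an open step

The source may report more compounds than this note shows. Statements on the series, on what has been measured and on what is new or still open speak of the compounds shown alone.

Compound 1 `COC(=O)C1=C(C)NC(c2nccs2)=NC1(C)c1ccc(F)cc1`: 22 ug/mL
Compound 2 `COC(=O)C1=C(C)NC(c2nccs2)=NC1(C)c1ccc(F)cc1Cl`: 18 ug/mL
Compound 3 `COC(=O)C1=C(C)NC(c2nccs2)=NC1(C)c1ccc(Cl)cc1`: 14 ug/mL

In a physicochemical assay for solubility, read by HPLC, in phosphate buffer, at pH 6.5 (a lower number here means a less soluble compound, a higher number a more soluble compound), compound 3 gives 14 ug/mL, which lies within the scatter of both compound 1 and compound 2. Compound 4 `COC(=O)C1=C(C)NC(c2nccs2)=NC1(C)c1ccc(S(C)(=O)=O)cc1` has methylsulfonyl in place of chloro on an aromatic carbon. Among the measured compounds shown here, three measured steps bear on this only indirectly: a 1.6-fold lower number from compound 1 to compound 3 (0.20 log units; within the scatter), a 1.2-fold lower number from compound 1 to compound 2 (0.09 log units; within the scatter) and a 1.3-fold lower number from compound 2 to compound 3 (0.11 log units; within the scatter). All of them exchange halogens or hydrogen, and none brings in a group like methylsulfonyl, so they are a weak guide. A small step toward a higher number in this assay is therefore expected, though it may not clear the scatter. The estimate means a 1.8-fold higher number from compound 3 to compound 4 (0.25 log units; within the scatter), as an expected step. For compound 4 the estimated value is 25 ug/mL, with an expected range of 8 ug/mL to 75 ug/mL.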

Compound 4, solubility: 365 ug/mL
Beside the measured number, compound 4's estimate is 15-fold (1.16 log units) below it, and the stated range ends below it.
By their numbers in this assay, from the lowest: compounds 3, 2 and 1 (each within the scatter of the next); then compound 4.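

In this assay the exchange of a halogen for methylsulfonyl on this aromatic carbon gives a 26-fold higher number from compound 3 to compound 4 (1.42 log units; beyond the scatter) and a 17-fold higher number from compound 1 to compound 4 (1.22 log units; beyond the scatter) in one move, both large, while the halogen and hydrogen exchanges all stayed within the scatter. Among the compounds shown here, this position, para to a large group, can therefore move the number far, which the earlier compounds did not show. Nothing at hand says what lies behind the step.
Open remains whether methylsulfonyl is special here or whether a carboxylic acid, an amine or a methyl sulfide at this place would give a like step. Also open, on these data alone, is whether a longer chain on the sulfonyl would keep it.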